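This account rests on a few compounds, and the source may have more. Where it says the series, first, only, none or still open, it means among the compounds named here.

Measured so far in a functional assay for inhibition, with Homo sapiens as the target; a higher number here means a weaker inhibitor, a lower number a stronger inhibitor:
- compound 1 `O=C(O)CCCCCCCn1nc(-c2ccccc2)c(-c2ccccc2)c1-c1ccccc1`: 3400 nM
- compound 2 `O=C(O)CCCCCCCCn1nc(-c2ccccc2)cc1-c1ccccc1`: > 66000 nM (a limit)
- compound 3 `O=C(O)CCCCCCCn1cc(-c2ccccc2)c(-c2ccccc2)n1`: > 85000 nM (a limit)

Compound 1 is the only one of the three with an actual number, and both limits lie on the weaker side of it.

Compound 4 `O=C(O)CS(=O)(=O)CCCCCCn1nc(-c2ccccc2)c(-c2ccccc2)c1-c1ccccc1` keeps the core of compound 1 and changes only the chain: (carboxymethyl)sulfonyl in place of carboxymethyl on a saturated chain carbon, six bonds along the chain from an aromatic nitrogen. Here (carboxymethyl)sulfonyl stands in place of carboxymethyl on a saturated chain carbon, six bonds along the chain from an aromatic nitrogen.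

For the measured compounds named here, no measured step covers a change of this kind. The nearest is an at least 25-fold higher number from compound 1 to compound 3 (1.39 log units; beyond the scatter), a large loss from hydrogen in place of phenyl on an aromatic carbon. That step concerns a different place, but it shows that a single change can cost this series heavily in this assay. A moderate move towards a higher number is therefore expected, with wide uncertainty: a 2.9-fold higher number from compound 1 to compound 4 (0.47 log units; beyond the scatter). For compound 4 the estimated value is 10000 nM, with an expected range from 2000 nM to 60000 nM.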

Compound 4, half-maximal inhibitory concentration: 22000 nM
Beside the measured number, compound 4's estimate is 2.2-fold (0.34 log units) below it; measured number inside the range.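

In this assay, swapping carboxymethyl for (carboxymethyl)sulfonyl on a saturated chain carbon, six bonds along the chain from an aromatic nitrogen, gives a 6.5-fold higher number from compound 1 to compound 4 (0.81 log units; beyond the scatter). For the compounds shown here, this is the first reading of a change in the chain itself: the loss is real but modest, and compound 4 keeps a measured value on the shared core with its carboxylic acid still in place. Nothing measured here explains the size of this step.

The compounds shown leave open whether the sulfonyl group itself or simply the greater length of the chain sets this loss, which a plain carbon chain of the same length would help to separate. They also leave open how an amide or an amine would fare at this position, in place of the sulfonyl group.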